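Triazene amides: from acetyl to trifluoromethylbenzoyl

The source may hold more compounds than are shown below. What is called first, only, known or untested is meant among the compounds shown, and "the series" means these compounds.

In a functional assay on HeLa cells (Homo sapiens) for cytotoxicity, read by MTT assay, with a stated time of 72 h (on this read-out lower numbers stand for stronger inhibition and higher numbers for weaker inhibition), two compounds have been measured so far. Compound 1 `CC(=O)Oc1ccc(/C=C/C(=O)N(/N=N/c2ccc(Cl)c(C(F)(F)F)c2)c2ccc(Cl)c(C(F)(F)F)c2)cc1OC(C)=O` gives 43000 nM, while compound 2 `CC(=O)N(/N=N/c1ccc([N+](=O)[O-])cc1Br)c1ccc([N+](=O)[O-])cc1Br` gives 550 nM. Within the data shown here, compound 2 therefore stands at the lowest of the two numbers, and the gap to compound 1 lies beyond the scatter of this assay; since the two compounds differ in several places at once, no single step between them is given, and only the two values themselves can be read.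

Compound 3 `O=C(c1ccccc1C(F)(F)F)N(/N=N/c1ccc([N+](=O)[O-])cc1Br)c1ccc([N+](=O)[O-])cc1Br` has not yet been measured. It differs from compound 2 in one place: 2-(trifluoromethyl)phenyl in place of methyl on a carbonyl carbon. The rest of the shared core, including both aryl groups on the triazene, is unchanged.

Among the measured compounds shown here, with no measured step available for a change of this kind, the expectation for compound 3 rests on the value of compound 2 in this assay. Compound 3 is expected to give about 1500 nM, with a range from 300 nM to 8000 nM. The step of a 2.7-fold higher number from compound 2 to compound 3 (0.44 log units; beyond the scatter) is thus estimated to be a modest loss of potency, of a size that may well sit near the edge of the scatter rather than far beyond it.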

Compound 3, half-maximal inhibitory concentration: 13300 nM
Estimate against measurement, compound 3: 8.9-fold (0.95 log units) below; measured number above the stated range.
By their numbers in this assay, from the lowest: compound 2; then compound 3; then compound 1.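

In this assay, among these compounds, putting 2-(trifluoromethyl)phenyl in place of methyl on the carbonyl carbon gives a 24-fold higher number from compound 2 to compound 3 (1.38 log units; beyond the scatter), the first step that can be read at this position. The step is large, so with both aryl groups on the triazene unchanged, the number in this assay clearly depends on what this carbonyl carbon carries. The exchange brings in a six-membered aromatic ring of carbon only, adds no hydrogen-bond donors or acceptors and no net charge, and no measurement at hand accounts for the size of the step.

This single step does not separate the part played by the phenyl ring from that of the trifluoromethyl on it, and a plain phenyl group would be needed to tell the two apart. Also open, from the compounds shown here alone, is how an ethyl or tert-butyl group, or a phenyl ring carrying a methoxy group or a carboxylic acid, would stand on the same carbonyl carbon, and whether the step would keep its size with other aryl groups on the triazene.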